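The source may report more compounds than this note shows. Statements on the series, on what has been measured and on what is new or still open speak of the compounds shown alone.

In an ADME assay on PBMC cells (Homo sapiens) for cytotoxicity (on this read-out higher numbers stand for lower toxicity in this test and lower numbers for higher toxicity in this test), compound 1 `CC(CCNC(=O)c1c(Cl)cncc1Cl)N1CCC(C(Oc2ccccn2)c2ccc(C(F)(F)F)cc2)CC1` gives 34100 nM. Compound 2 `Cc1cccc(OC(c2ccc(C(F)(F)F)cc2)C2CCN(C(C)CCNC(=O)c3c(Cl)cncc3Cl)CC2)n1` gives 6700 nM in this assay, and compound 3 `CC(CCNC(=O)c1c(Cl)cncc1Cl)N1CCC(C(Oc2ccccc2)c2ccc(C(F)(F)F)cc2)CC1` gives 6800 nM. Among these three numbers compound 3 stands second highest: its nearest neighbour is compound 2, within the scatter, while the gap to compound 1 is beyond it. The step from compound 3 to compound 4 `CC(CCNC(=O)c1c(Cl)cncc1Cl)N1CCC(C(Oc2cccc(C(=O)O)n2)c2ccc(C(F)(F)F)cc2)CC1` replaces one aromatic ring by another: 6-carboxypyridin-2-yl in place of phenyl on an oxygen on a saturated carbon. Within the data shown here, two measured steps touch the same position. One of them, a 5.0-fold lower number from compound 1 to compound 3 (0.70 log units; beyond the scatter), shows that removing the ring nitrogen lowered the number by a modest but real amount; the other, a 1.0-fold higher number from compound 2 to compound 3 (0.01 log units; within the scatter), shows no change beyond the scatter. Compound 4 restores the ring nitrogen and adds a carboxylic acid, so he expects the number to move back up, with a step of roughly a 4.4-fold higher number from compound 3 to compound 4 (0.64 log units; beyond the scatter) expected. His estimate for compound 4 in this assay is therefore 30000 nM, with a range from 8000 nM to 100000 nM.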

Compound 4, half-maximal cytotoxic concentration: 28700 nM
The estimate for compound 4 lay 1.0-fold (0.02 log units) above the measured number, within the range that was stated.
By their numbers in this assay, from the lowest: compounds 2 and 3 (each within the scatter of the next); then compounds 4 and 1 (each within the scatter of the next).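

Adding a carboxy group to an aromatic carbon gives a 1.2-fold lower number from compound 1 to compound 4 (0.07 log units; within the scatter) in this assay, whereas methyl in that place gave a 5.1-fold lower number from compound 1 to compound 2 (0.71 log units; beyond the scatter), so this carbon does not respond alike to every group placed on it. Carboxy in place of methyl gives a 4.3-fold higher number from compound 2 to compound 4 (0.63 log units; beyond the scatter), and the whole exchange of phenyl for 6-carboxypyridin-2-yl gives a 4.2-fold higher number from compound 3 to compound 4 (0.63 log units; beyond the scatter), so the carboxy-bearing ring stands apart from both lower compounds and level with the unsubstituted pyridin-2-yl of compound 1. Nothing available explains why the methyl and carboxy groups part in this way.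

The compounds shown leave open whether a methyl ester or a primary amide in place of the carboxy group would read like compound 4 or like compound 2. They also leave open how a carboxy group on the phenyl ring of compound 3 would read without the ring nitrogen.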